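Replacing acetyl with (pyrrolidin-1-yl)methyl in compound 2

A few compounds are considered here, and "the series" means these few. Any claim that something is new, unique, unknown or untested is made for them only; others in the source may bear on it.

Measured in a functional assay on MV4-11 cells (Homo sapiens) for inhibition, read by resazurin assay, with a stated time of 72 h; on this read-out higher numbers stand for weaker inhibition of growth and lower numbers for stronger inhibition of growth:
compound 1 `O=C1NCCC12CCN(c1c(Cl)cncc1-c1ccc(Cl)s1)CC2`: 560 nM
compound 2 `CC(=O)c1ccc(-c2cncc(Cl)c2N2CCC3(CCNC3=O)CC2)s1`: 1440 nM
compound 3 `Cc1cc(-c2cncc(Cl)c2N2CCC3(CCNC3=O)CC2)sc1C=O`: 2530 nM

Compound 2 stands apart from compound 1, with a 2.6-fold higher number from compound 1 to compound 2 (0.41 log units; beyond the scatter), but a 1.8-fold higher number from compound 2 to compound 3 (0.24 log units; within the scatter) leaves it within the scatter of compound 3. Compound 4 `O=C1NCCC12CCN(c1c(Cl)cncc1-c1ccc(CN3CCCC3)s1)CC2` has (pyrrolidin-1-yl)methyl in place of acetyl on an aromatic carbon, next to the ring sulfur: (pyrrolidin-1-yl)methyl in place of acetyl on an aromatic carbon. Substitution at this place has so far given modest steps, with a 4.5-fold higher number from compound 1 to compound 3 (0.65 log units; beyond the scatter) alongside the step from chloro to acetyl. None of the three measured compounds carries a (pyrrolidin-1-yl)methyl group, so the direction is poorly defined. A modest change is the most that these steps support, with a slight lean towards compound 1. The estimate therefore means a 1.4-fold lower number from compound 2 to compound 4 (0.16 log units; within the scatter), an expected step that does not clearly exceed the scatter. Compound 4 is expected at 1000 nM in this assay, with an estimated range from 330 nM to 3000 nM as the likely span.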

Compound 4, concentration for 50% growth inhibition: 3370 nM
Compound 4: middle estimate off by 3.4-fold (0.53 log units), on the low side; measured number outside the range, above it.
By their numbers in this assay, from the lowest: compound 1; then compounds 2, 3 and 4 (each within the scatter of the next, the first and the last beyond it).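

In this assay, the (pyrrolidin-1-yl)methyl group on this aromatic carbon, next to the ring sulfur, gives weaker inhibition of growth than either acetyl (a 2.3-fold higher number from compound 2 to compound 4 (0.37 log units; beyond the scatter)) or chloro (a 6.0-fold higher number from compound 1 to compound 4 (0.78 log units; beyond the scatter)). The earlier replacements of chloro at this place both carried a carbonyl, whereas compound 4 has none and still gives a higher number than compound 1, so the loss is not confined to carbonyl groups. Nothing available explains this rise.

The compounds shown leave open whether a smaller group, such as fluoro or methyl, would hold the growth inhibition of compound 1 at this place. They also leave open whether an open-chain amine such as dimethylaminomethyl, or a carboxylic acid, would follow compound 4.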